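A few compounds are considered here, and "the series" means these few. Any claim that something is new, unique, unknown or untested is made for them only; others in the source may bear on it.

Series in a functional assay on SF-539 cells (Homo sapiens) for antiproliferative activity; on this read-out higher numbers stand for weaker inhibition of growth and lower numbers for stronger inhibition of growth:
- compound 1 `CCCCCCNC(=O)c1cc(CCc2cc(O)ccc2O)ccc1O`: 2200 nM
- compound 2 `CCCCCCNC(=O)c1cc(C#Cc2cc(OC)ccc2OC)ccc1OC`: > 100000 nM, a limit of the assay
- compound 3 `COC(=O)c1cc(/C=C\c2cc(OC)ccc2OC)ccc1OC`: 10600 nM

Among the actual numbers, compound 3 at 10600 nM stands highest, and compound 1 at 2200 nM is lower by a gap beyond the scatter. Compound 2 gives only a limit, > 100000 nM.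

Still to be measured is compound 4 `CCCCCCNC(=O)c1cc(/C=C\c2cc(OC)ccc2OC)ccc1OC`, which has hexylamino in place of methoxy on a carbonyl carbon of compound 3 (hexylamino in place of methoxy on a carbonyl carbon). The same difference reads methoxycarbonyl to hexylcarbamoyl. For the measured compounds named here, no measured pair isolates this change in this assay, so the guide is indirect and mixed. Hexylcarbamoyl is also present in compound 1, at 2200 nM. It is present in compound 2 as well, which reaches only the limit > 100000 nM.

A small expected move toward stronger inhibition of growth, near the edge of the scatter, rests on compound 1 at 2200 nM, with compound 2 as the warning against it. The expected change is a 2.1-fold lower number from compound 3 to compound 4 (0.33 log units; beyond the scatter). For compound 4 the estimated value is 5000 nM, with an estimated range of 800 nM to 30000 nM.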

Compound 4, concentration for 50% growth inhibition: 23600 nM
Estimate against measurement, compound 4: 4.7-fold (0.67 log units) below; measured number inside the range.
By their numbers in this assay, from the lowest: compound 1; then compound 3; then compound 4. At a limit, above all of these: compound 2.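

Read alone on this carbonyl carbon, hexylamino in place of methoxy gives a 2.2-fold higher number from compound 3 to compound 4 (0.35 log units; beyond the scatter) in this assay, a modest loss of inhibition of growth. Hexylcarbamoyl therefore brings no gain on the core of compound 3, and the stronger inhibition of growth of compound 1 (2200 nM) cannot be credited to that group, since compound 1 differs from compound 4 in more than one place. Compound 2, which also carries hexylcarbamoyl, gives > 100000 nM as a limit of the assay, whereas compound 4 gives a real number.

Nothing shown bears on the cause of this step. Still open, as far as these compounds go, is whether a carboxylic acid or a shorter chain such as butylamino on the same carbonyl carbon would move the number the same way.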